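Side-chain swap on the shared core

The source may report more compounds than this note shows. Statements on the series, on what has been measured and on what is new or still open speak of the compounds shown alone.

Compound 1 `O=[N+]([O-])c1cn(CCS(=O)(=O)NCCO)cn1` and compound 2 `COCCCNS(=O)(=O)CCn1c([N+](=O)[O-])cnc1C` share the core; in a functional assay on HCT-116 cells (Homo sapiens) for cytotoxicity, read by sulforhodamine B assay, with stated times of 4 h and 5 days (on this read-out higher numbers stand for weaker inhibition and lower numbers for stronger inhibition), compound 1 gives 10900000 nM and compound 2 gives 3700000 nM. Compound 2 thus holds the lower of the two numbers, and its gap to compound 1 lies beyond the scatter. Compound 3 `Cc1ncc([N+](=O)[O-])n1CCS(=O)(=O)NCCN(C)C` differs from compound 2 by dimethylamino in place of methoxymethyl on a saturated chain carbon, two bonds along the chain from a sulfonamide nitrogen. Among the measured compounds shown here, no step of this kind has been measured, so no shift beyond the scatter is expected in this assay in either direction. For compound 3 the expected value is 3500000 nM, within a range of 1200000 nM to 10000000 nM, an expected step of a 1.1-fold lower number from compound 2 to compound 3 (0.02 log units; within the scatter).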

Compound 3, half-maximal inhibitory concentration: 800000 nM
The estimate for compound 3 lay 4.4-fold (0.64 log units) above the measured number; the measured number lies below the stated range.
By their numbers in this assay, from the lowest: compound 3; then compound 2; then compound 1.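

In this assay, this position proves sensitive to the change: dimethylamino in place of methoxymethyl gives a 4.6-fold lower number from compound 2 to compound 3 (0.67 log units; beyond the scatter). The two groups match in heavy atoms, hydrogen-bond donors, hydrogen-bond acceptors and net charge, and differ in that nitrogen stands where oxygen stood. No measurement at hand accounts for the shift.

This single step leaves open whether the shift follows amines generally or is specific to dimethylamino. Also open, going by these compounds, is how a carboxylic acid, a piperidine or a longer chain carrying dimethylamino would read at this position.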